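Methanesulfonyl capping of the aminopyridine on two cores

This account rests on a few compounds, and the source may have more. Where it says the series, first, only, none or still open, it means among the compounds named here.

Compound 1 `C[C@H](NC(=O)c1ccc(-c2ccc(N)nc2)cc1)C(=O)Nc1ccc(Cl)c(C(F)(F)F)c1` and compound 3 `Nc1ccc(-c2ccc(C(=O)N[C@H]3CN[C@@H](C(=O)Nc4ccc(Cl)c(C(F)(F)F)c4)C3)cc2)cn1` carry different cores; the difference between the two cores is not broken down here. In a functional assay on K562 cells (Homo sapiens) for inhibition, read by MTT assay, with a stated time of 48 h (a lower number here means a stronger inhibitor, a higher number a weaker inhibitor), compound 1 gives 5950 nM and compound 3 gives 9130 nM, two values that lie within the scatter of each other. Compound 2 `CS(=O)(=O)Nc1ccc(-c2ccc(C(=O)N[C@H]3CN[C@@H](C(=O)Nc4ccc(Cl)c(C(F)(F)F)c4)C3)cc2)cn1` arises from compound 3 by methylsulfonyl in place of hydrogen on a nitrogen on an aromatic ring, and in this assay compound 2 gives 45000 nM, so that the step is a 4.9-fold higher number from compound 3 to compound 2 (0.69 log units; beyond the scatter). Compound 4 `C[C@H](NC(=O)c1ccc(-c2ccc(NS(C)(=O)=O)nc2)cc1)C(=O)Nc1ccc(Cl)c(C(F)(F)F)c1` arises from compound 1 by the same change, (methylsulfonyl in place of hydrogen on a nitrogen on an aromatic ring), at an identically described place. Because the same change on the other core gave a 4.9-fold higher number from compound 3 to compound 2 (0.69 log units; beyond the scatter), the step from compound 1 to compound 4 in this assay is expected to be of similar size, estimated as a 4.2-fold higher number from compound 1 to compound 4 (0.62 log units; beyond the scatter). For compound 4 in this assay the estimate is 25000 nM, expected to fall between 10000 nM and 60000 nM.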

Compound 4, half-maximal inhibitory concentration: 7240 nM
Beside the measured number, compound 4's estimate is 3.5-fold (0.54 log units) above it; measured number below the stated range.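

The methylsulfonyl change does not carry over at the same size between the two cores in this assay: the same change on two cores in this assay, a 4.9-fold higher number (0.69 log units; beyond the scatter) from compound 3 to compound 2 and a 1.2-fold higher number (0.09 log units; within the scatter) from compound 1 to compound 4, 4.1-fold (0.61 log units) apart, beyond the scatter of two such steps. The new step, a 1.2-fold higher number from compound 1 to compound 4 (0.09 log units; within the scatter), lies within the scatter, so on this core the 6-aminopyridin-3-yl to 6-(methanesulfonamido)pyridin-3-yl change has no readable effect on the number. The two pairs show that the size of this step depends on the core, but they do not show which feature of the cores is responsible, and they give no rule for a third core.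

Still open, going by these compounds, is whether an acetyl or ethylsulfonyl group on the same nitrogen would also behave differently on the two cores.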